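Notes on an aryl swap on the shared core

The compounds below may be only part of what the source reports. "The series", "measured", "known", "first", "only" and "open" are said of these compounds alone.

Compound 1 `Cn1c(-c2cccc(Cl)c2)nc2c(NC3CCCC3)ncnc21` has the lowest of the two numbers given in a functional assay on CHO cells for antagonist activity at adenosine receptor A2b (Homo sapiens), read by 33P incorporation, with a stated time of 20 min (a lower number here means a stronger inhibitor, a higher number a weaker inhibitor), where compound 1 gives 2530 nM. Compound 3 `CCCn1c(-c2ccccc2)nc2c(NC3CCOC3)ncnc21` stands beyond the scatter from it: in this assay compound 3 gives 9080 nM. Compound 2 `Cn1c(-c2ccccc2)nc2c(NC3CCCCC3)ncnc21` reaches only a limit of this assay, > 30000 nM, which is the limit of > 30000 nM in this assay, at which 1 of the 3 values shown sits. Compound 4 `Cn1c(-c2ccc(O)cc2)nc2c(NC3CCCC3)ncnc21` is not yet measured; it differs from compound 1 by 4-hydroxyphenyl in place of 3-chlorophenyl on an aromatic carbon. Among the measured compounds shown here, no single-change step between measured compounds exists in this set, so the size of the step is taken from the spread alone; a modest step toward a stronger inhibitor, near the edge of the scatter, is expected, a 1.4-fold lower number from compound 1 to compound 4 (0.15 log units; within the scatter). Compound 4 is estimated at 1800 nM, with a range from 400 nM to 8000 nM.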

Compound 4, inhibition constant: 17800 nM
For compound 4 the middle estimate is 9.9-fold (1.00 log units) below the measured one, outside the stated range (above it).
By their numbers in this assay, from the lowest: compound 1; then compounds 3 and 4 (each within the scatter of the next). At a limit, above all of these: compound 2.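

In this assay, the aryl group on the aromatic carbon between two ring nitrogen atoms gives the series its first single-change step, a 7.0-fold higher number from compound 1 to compound 4 (0.85 log units; beyond the scatter), so this place is not indifferent to 4-hydroxyphenyl in place of 3-chlorophenyl. The swap alters the ring substituent and its numbered place together, and this step cannot separate the two. No measurement shown bears on a cause for the step.

Still open, going by these compounds, is whether 4-chlorophenyl or 3-hydroxyphenyl on the same core would stand with compound 1 or with compound 4.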